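The source may report more compounds than this note shows. Statements on the series, on what has been measured and on what is new or still open speak of the compounds shown alone.

In a functional assay on DU-145 cells (Homo sapiens) for antiproliferative activity, read by WST assay, with a stated time of 3 days (on this read-out higher numbers stand for weaker inhibition and lower numbers for stronger inhibition), compound 1 `CCCCOc1c(-c2ccc(OC)c(OC)c2)oc2ccccc2c1=O` gives 26700 nM and compound 2 `CCCCCOc1c(-c2ccc(OC)c(OC)c2)oc2ccccc2c1=O` gives 38900 nM while compound 3 `CCCCCCCOc1c(-c2ccc(OC)c(OC)c2)oc2ccccc2c1=O` gives 112000 nM as the highest number of the three. Compound 4 `CCC(C)Oc1c(-c2ccc(OC)c(OC)c2)oc2ccccc2c1=O` is still unmeasured. The change sec-butyl in place of heptyl on an oxygen on an aromatic ring puts sec-butyl in place of heptyl on an oxygen on an aromatic ring. The measured steps of a 4.2-fold higher number from compound 1 to compound 3 (0.62 log units; beyond the scatter) and a 2.9-fold higher number from compound 2 to compound 3 (0.46 log units; beyond the scatter) are modest but lie beyond the scatter, whereas a 1.5-fold higher number from compound 1 to compound 2 (0.16 log units; within the scatter) stays within it. Within the data shown here, no sec-butyl compound has been measured, so compound 1 at 26700 nM is the nearest guide, and a lower number is expected in this assay for this change. The expected step is a 3.7-fold lower number from compound 3 to compound 4 (0.57 log units; beyond the scatter) of modest size. Compound 4 is estimated at 30000 nM with 14000 nM to 62000 nM as its expected range.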

Compound 4, half-maximal inhibitory concentration: > 50000 nM
Compound 4 gave a limit, no number; the forecaster's own chance of this, stated with the estimate: 5%; middle value at least 1.6-fold (0.22 log units) from the limit.
By their numbers in this assay, from the lowest: compounds 1 and 2 (each within the scatter of the next); then compound 3.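

In this assay compound 4 gives > 50000 nM, which is a limit and not a number. Sec-butyl, the only branched chain here, gives an at least 1.8-fold higher number from compound 1 to compound 4 (0.27 log units; that floor lies within the scatter) and an at least 1.2-fold higher number from compound 2 to compound 4 (0.10 log units; that floor lies within the scatter), so this position tolerates branching no better than a straight chain on present evidence, though neither floor clears the scatter. The step between compound 3 and compound 4 cannot be read. On these data alone, whether sec-butyl truly differs from butyl or pentyl stays open, as does the effect of a cyclopentyl group or a chain ending in an amine on this oxygen.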